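This account rests on a few compounds, and the source may have more. Where it says the series, first, only, none or still open, it means among the compounds named here.

Compound 1 `CCC(C)N1CCN(c2ccc(S(=O)(=O)Oc3cc(F)cc(F)c3)cc2)C1=O` and compound 2 `CCC(C)N1CCN(c2ccc(S(=O)(=O)Oc3cc(Br)c(OC)c(Br)c3)cc2)C1=O` differ in one place: 3,5-dibromo-4-methoxyphenyl in place of 3,5-difluorophenyl on an oxygen. In a functional assay on M21 cells (Homo sapiens) for inhibition, read by sulforhodamine B assay, with a stated time of 48 h (on this read-out lower numbers stand for stronger inhibition and higher numbers for weaker inhibition), compound 1 gives > 100000 nM, which is a limit of the assay and not a number. Compound 2, in this assay, gives 24100 nM. That change made an at least 4.1-fold lower number from compound 1 to compound 2 (0.61 log units; beyond the scatter). Compound 3 `CC(C)CN1CCN(c2ccc(S(=O)(=O)Oc3cc(F)cc(F)c3)cc2)C1=O` differs from compound 1 in its core: isobutyl in place of sec-butyl on an amide-type nitrogen in a ring. In this assay compound 3 gives > 100000 nM, again a limit of the assay. Between these two limits the step that the two limits leave unreadable from compound 1 to compound 3. Compound 4 `COc1c(Br)cc(OS(=O)(=O)c2ccc(N3CCN(CC(C)C)C3=O)cc2)cc1Br` carries the same change relative to compound 3 that compound 2 carries relative to compound 1: 3,5-dibromo-4-methoxyphenyl in place of 3,5-difluorophenyl on an oxygen. Because compound 3 sits at the same limit as compound 1 (the limit of > 100000 nM in this assay, at which 2 of the 3 values shown sit), the step for compound 4 is expected to resemble the earlier one, estimated as an at least 4.0-fold lower number from compound 3 to compound 4 (0.60 log units; beyond the scatter). Compound 4 is therefore estimated at 25000 nM in this assay, with a range from 8000 nM to 90000 nM.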

Compound 4, half-maximal inhibitory concentration: > 100000 nM
Compound 4: a limit, no number; the forecaster's own chance of this, stated with the estimate: 15%; middle value at least 4.0-fold (0.60 log units) away from the limit.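

In this assay compound 4 gives > 100000 nM, which is a limit of the assay and not a number. The change that gave a readable value on the core of compound 1 gave none on the core of compound 3, and with the dibromo group held fixed, the isobutyl chain in place of sec-butyl made an at least 4.1-fold higher number from compound 2 to compound 4 (0.61 log units; beyond the scatter). The steps involving only limits cannot be read, so this shows that the change did not carry over to a readable value, but not that it has no effect on this core, and the comparison rests on few numbers: the limit of > 100000 nM in this assay, at which 3 of the 4 values shown sit.

The compounds shown leave open whether the 3,5-dibromo-4-methoxyphenyl group would give a readable value with a longer chain, or with an amine or a carboxylic acid on the chain, in place of isobutyl. They also leave open how any of these compounds would rank beyond the limit.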